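The source may hold more compounds than are shown below. What is called first, only, known or untested is meant among the compounds shown, and "the series" means these compounds.

Measured so far in a functional assay on PC-3 cells (Homo sapiens) for cytotoxicity, read by MTT assay; a lower number here means a stronger inhibitor, a higher number a weaker inhibitor:
Compound 1 `COc1cccc(/C=C/C(=O)c2sc(Nc3ccc(Cl)c(Cl)c3)nc2C)c1` gives 10100 nM.
Compound 2 `Cc1nc(Nc2cccc(Cl)c2)sc1C(=O)/C=C/c1ccc(Cl)cc1` gives > 25000 nM, a limit of the assay.
Compound 3 `Cc1nc(Nc2ccc(Cl)c(Cl)c2)sc1C(=O)/C=C/c1ccc(Cl)cc1` gives > 25000 nM, likewise a limit.

Compound 3 therefore stands at the limit of > 25000 nM in this assay, at which 2 of the 3 values shown sit, and has no number of its own. Compound 4 is `Cc1nc(Nc2ccc(Cl)cc2)sc1C(=O)/C=C/c1ccc(Cl)cc1`; it differs from compound 3 by hydrogen in place of chloro on an aromatic carbon. Among the measured compounds shown here, the one measured step of the same kind, a step that the two limits leave unreadable from compound 2 to compound 3, runs between two limits and gives no size; an at least 2.4-fold higher number from compound 1 to compound 3 (0.39 log units; beyond the scatter) concerns a different part of the molecule and only sets a floor. For the measured compounds named here, no measured step fixes a direction for this change, so nothing beyond the scatter is expected, and compound 4 is expected at a number no higher from compound 3 to compound 4 (the limit leaves the size open). Compound 4 is estimated at 25000 nM, in the range 8000 nM to 80000 nM, most likely reported as a limit again.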

Compound 4, half-maximal inhibitory concentration: > 25000 nM
Compound 4 gave a limit, no number; the forecaster's own chance of this, stated with the estimate: 70%; the middle value lies on the limit itself.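

Compound 2, compound 3 and compound 4 all give limits, not numbers, in this assay, so no new step among them can be read: the limit of > 25000 nM in this assay, at which 3 of the 4 values shown sit.
On these data alone, whether the 3-chlorophenyl, 4-chlorophenyl and 3,4-dichlorophenyl groups differ at all in this read-out remains open.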